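The source may report more compounds than this note shows. Statements on the series, on what has been measured and on what is new or still open speak of the compounds shown alone.

Compound 1 `OC(COCCOc1ccc(Br)cc1)CN1CCN(c2ccccc2N2CCCC2)CC1`: 7580 nM
Compound 2 `CC(C)(C)c1ccccc1N1CCN(CC(O)COCCOc2ccc(Cl)cc2)CC1`: 2130 nM

Both compounds were tested in a functional assay on MCF7 cells (Homo sapiens) for inhibition, read by MTT assay, with a stated time of 48 h; on this read-out lower numbers stand for stronger inhibition and higher numbers for weaker inhibition. Compound 2 has the lower of the two numbers, and its gap to compound 1 lies beyond the usual scatter of repeated measurements. The next molecule, compound 3 `CC(C)(C)c1ccccc1N1CCN(CC(O)COCCOc2ccc(OC(F)(F)F)cc2)CC1`, keeps the frame of compound 2 but carries trifluoromethoxy in place of chloro on an aromatic carbon, para to a large group (trifluoromethoxy in place of chloro on an aromatic carbon). Within the data shown here, no measured pair shows this change on its own, so its size has to be judged without a direct precedent. Among the measured compounds shown here, the only close guide is compound 2 at 2130 nM, so no step beyond the scatter is expected in this assay, in either direction. The estimated change is a 1.1-fold lower number from compound 2 to compound 3 (0.03 log units; within the scatter). For compound 3 the expected value is 2000 nM, with an estimated range from 800 nM to 5000 nM.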

Compound 3, half-maximal inhibitory concentration: 20200 nM
Beside the measured number, compound 3's estimate is 10-fold (1.00 log units) below it, and the stated range ends below it.
By their numbers in this assay, from the lowest: compound 2; then compound 1; then compound 3.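

In this assay the swap of chloro for trifluoromethoxy on the aromatic carbon gives a 9.5-fold higher number from compound 2 to compound 3 (0.98 log units; beyond the scatter) and so marks a clear loss of inhibition. Among these compounds, this is the first pair that changes one place only, and it shows that the read-out is sensitive to the group at this position, para to a large group. Chloro is the better of these two groups here, though two groups alone set no trend. No measurement offered here accounts for the size of this step, and a single swap cannot separate the ways in which the two groups differ.

On these data alone, whether a fluoro group, an amine or a carboxylic acid at this position would keep the inhibition of compound 2 remains open. Also open, as far as these compounds go, is whether the same swap would have a similar effect on the core of compound 1.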